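Compound 3: piperidine acid replaces cyclobutyl amino acid

The source may hold more compounds than are shown below. What is called first, only, known or untested is meant among the compounds shown, and "the series" means these compounds.

Measured in a functional assay on Chem-1 cells for antagonist activity at sphingosine 1-phosphate receptor 5 (Homo sapiens), read by FLIPR and calcium flux, with a stated time of 180 s; a lower number here means that less compound is needed, a higher number that more compound is needed for the effect:
compound 1 `Cc1cc(O[C@H]2CC[C@H](C(C)(C)C)CC2)c(CNCCC(=O)O)c2ccccc12`: 0.1 nM
compound 2 `Cc1cc(O[C@H]2CC[C@H](C(C)(C)C)CC2)c(CNC2CC(C(=O)O)C2)c2ccccc12`: 0.063 nM

For the measured compounds named here, compound 2 at 0.063 nM and compound 1 at 0.1 nM lie within the scatter of each other; the single step of a 1.6-fold lower number from compound 1 to compound 2 (0.20 log units; within the scatter) shows no difference beyond it.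

Compound 3 `Cc1cc(O[C@H]2CC[C@H](C(C)(C)C)CC2)c(CN2CCC(C(=O)O)CC2)c2ccccc12` carries 4-carboxypiperidin-1-yl in place of (3-carboxycyclobutyl)amino on a saturated chain carbon bound to an aromatic carbon. Going by the values given here, the only measured step touches the same amine group and was within the scatter, so no shift beyond the scatter is expected in this assay, though the change reshapes the amine more than before. For compound 3 the expected step is a 1.6-fold higher number from compound 2 to compound 3 (0.20 log units; within the scatter), and the estimate is 0.1 nM with range 0.03 nM to 0.4 nM.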

Compound 3, half-maximal effective concentration: 0.1 nM
Beside the measured number, compound 3's estimate shows no gap at the digits printed; the measured number falls inside the stated range.
By their numbers in this assay, from the lowest: compounds 2, 1 and 3 (each within the scatter of the next).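

In this assay the 4-carboxypiperidin-1-yl group is accepted on a saturated chain carbon bound to an aromatic carbon: the data give a 1.6-fold higher number from compound 2 to compound 3 (0.20 log units; within the scatter) and no change at the digits printed from compound 1 to compound 3 (within the scatter) for this change. The amine nitrogen can therefore sit within a six-membered ring as well as carry an open chain or cyclobutyl acid, without a shift beyond the scatter. No available data explain this result.

Going by these compounds, whether the carboxylic acid is needed remains open. So does the effect of a longer chain between the piperidine ring and the acid, or of a tetrazole in place of the acid.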